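This account rests on a few compounds, and the source may have more. Where it says the series, first, only, none or still open, it means among the compounds named here.

Working notes on the series. Among the compounds with values here, compound 1 `CN1CCc2ccccc2Cc2sc3ccccc3c2CC1` is the only compound of this set with a numerical value in an assay on isolated protein for binding affinity to D(4) dopamine receptor (Homo sapiens), read by radioligand binding, with a stated time of 90 min; on this read-out higher numbers stand for weaker inhibition and lower numbers for stronger inhibition: there compound 1 gives 72 nM. Within the data shown here, the one further value on record is not a number: compound 2 `CCOC(=O)N1CCc2ccccc2Cc2sccc2CC1` comes out at the limit > 1000 nM in this assay, a limit only. Among the measured compounds shown here, compound 1 and compound 2 differ in more than one place, so their two values show no single step.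

The step under consideration leads from compound 1 to compound 3 `CCOC(=O)N1CCc2ccccc2Cc2sc3ccccc3c2CC1` through ethoxycarbonyl in place of methyl on an amine nitrogen in a ring — ethoxycarbonyl in place of methyl on an amine nitrogen in a ring. For the measured compounds named here, no measured pair of this series carries the same single change. Compound 2 also bears the ethoxycarbonyl group on its ring amine and reaches only the limit > 1000 nM in this assay, as recorded in the limit of > 1000 nM in this assay, at which 1 of the 2 values shown sits. The expectation for compound 3 is therefore a weakening well beyond the scatter, a 21-fold higher number from compound 1 to compound 3 (1.32 log units; beyond the scatter). Compound 3 is estimated at 1500 nM in this assay, in the range 300 nM to 8000 nM, with a fair chance that only a limit is reported.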

Compound 3, inhibition constant: > 1000 nM
Compound 3 gave a limit, no number; the forecaster's own chance of this, stated with the estimate: 55%; the middle value does not contradict the limit.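

With compound 3, the amine nitrogen in the ring gets its first single-place reading in this assay: ethoxycarbonyl in place of methyl gives an at least 13-fold higher number from compound 1 to compound 3 (1.14 log units; beyond the scatter). The value of compound 3, > 1000 nM, is a limit and not a number, so this step fixes a minimum size only. Both compounds shown with ethoxycarbonyl on this nitrogen now sit at the limit, and only compound 1, with methyl there, gives a number: the limit of > 1000 nM in this assay, at which 2 of the 3 values shown sit.

Open, as far as these compounds go, is whether the carbonyl or the added chain length accounts for the step, a question that an ethyl or propyl group or an acetyl group on the same nitrogen would address. Also open, from the compounds shown here alone, is how the bare secondary amine or a benzyl group at this nitrogen would read in this assay.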